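From 3,4-dichlorophenyl to 4-fluorophenyl: a modest expected gain

The source may report more compounds than this note shows. Statements on the series, on what has been measured and on what is new or still open speak of the compounds shown alone.

In a functional assay on FM3A cells (Mus musculus) for antiproliferative activity (on this read-out higher numbers stand for weaker inhibition and lower numbers for stronger inhibition), compound 1 `COc1cc(C(=O)c2sc(-c3cccc([N+](=O)[O-])c3)cc2N)cc(OC)c1OC` gives 17 nM, compound 2 `COc1cc(C(=O)c2sc(-c3ccncc3)cc2N)cc(OC)c1OC` gives 150 nM, and compound 3 `COc1cc(C(=O)c2sc(-c3ccc(Cl)c(Cl)c3)cc2N)cc(OC)c1OC` gives 400 nM, the highest number and so the weakest inhibition of the three. Compound 4 `COc1cc(C(=O)c2sc(-c3ccc(F)cc3)cc2N)cc(OC)c1OC` keeps the shared core and changes one group: 4-fluorophenyl in place of 3,4-dichlorophenyl, (4-fluorophenyl in place of 3,4-dichlorophenyl on an aromatic carbon). Two measured steps changed the same group: a 24-fold higher number from compound 1 to compound 3 (1.37 log units; beyond the scatter), which is large, and a 2.7-fold higher number from compound 2 to compound 3 (0.43 log units; beyond the scatter), which is modest. Neither involves 4-fluorophenyl, so they offer only loose guidance. With the starting point at the top of the measured range, a modest move to a lower number is expected, a 4.0-fold lower number from compound 3 to compound 4 (0.60 log units; beyond the scatter). The estimate for compound 4 is 100 nM, within a range of 25 nM to 400 nM.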

Compound 4, half-maximal inhibitory concentration: 16 nM
Beside the measured number, compound 4's estimate is 6.3-fold (0.80 log units) above it; the measured number lies below the stated range.
By their numbers in this assay, from the lowest: compounds 4 and 1 (each within the scatter of the next); then compound 2; then compound 3.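

In this assay, the group next to the ring sulfur can move the number a long way, as 4-fluorophenyl in place of 3,4-dichlorophenyl gives a large drop (a 25-fold lower number from compound 3 to compound 4 (1.40 log units; beyond the scatter)). It also beats pyridin-4-yl (a 9.4-fold lower number from compound 2 to compound 4 (0.97 log units; beyond the scatter)), yet compound 4 cannot be told apart from the 3-nitrophenyl compound (a 1.1-fold lower number from compound 1 to compound 4 (0.03 log units; within the scatter)), so two differently substituted phenyl groups both reach the low end of the range. Nothing measured here explains these differences.

Going by these compounds, whether the gain comes from losing one chlorine or from replacing the other with fluorine stays open. A 4-chlorophenyl or an unsubstituted phenyl group would separate the two.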